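A Bulkier, Hydroxylated Amide Ring on a Receptor Inhibitor

The source may report more compounds than this note shows. Statements on the series, on what has been measured and on what is new or still open speak of the compounds shown alone.

Measured so far:
compound 1 `COc1cc(C(=O)N2CCC(C)(C)C2)cc2nc(NCc3cccc(Cl)c3)oc12` — 40 nM
compound 2 `COc1cc(C(=O)N2CCC(O)C(C)C2)cc2nc(NCc3cc(Cl)ccc3F)oc12` — 300 nM

In an assay on isolated protein for inhibition of thyroid hormone receptor beta (Homo sapiens), read by fluorescence, with a stated time of 30 min (a lower number here means a stronger inhibitor, a higher number a weaker inhibitor), compound 1 gives 40 nM, the lower of the two numbers; compound 2 gives 300 nM, a weaker result beyond the scatter. Compound 3 `COc1cc(C(=O)N2CC(C)C(O)CC2CCO)cc2nc(NCc3cccc(Cl)c3)oc12` is not yet measured. It differs from compound 1 in one place: 4-hydroxy-2-(2-hydroxyethyl)-5-methylpiperidin-1-yl in place of 3,3-dimethylpyrrolidin-1-yl on a carbonyl carbon. The amide ring grows and gains hydroxyl groups. Compound 2, which differs from compound 1 in its amide ring and elsewhere, gives the weaker number, so a moderate loss beyond the scatter is expected, a 3.8-fold higher number from compound 1 to compound 3 (0.57 log units; beyond the scatter). Compound 3 is estimated at 150 nM, within 50 nM to 500 nM.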

Compound 3, half-maximal inhibitory concentration: 0.27 nM
For compound 3 the middle estimate is 560-fold (2.74 log units) above the measured one; the whole stated range lies above it.
By their numbers in this assay, from the lowest: compound 3; then compound 1; then compound 2.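

In this assay, placing 4-hydroxy-2-(2-hydroxyethyl)-5-methylpiperidin-1-yl on the carbonyl carbon instead of 3,3-dimethylpyrrolidin-1-yl gives a 150-fold lower number from compound 1 to compound 3 (2.17 log units; beyond the scatter) and so a much stronger inhibitor. This position therefore accepts a larger six-membered ring carrying hydroxyl groups, and a change here alone can move the number greatly. Nothing measured here explains why the number falls so far.

Ring size, both hydroxyl groups and the methyl all change in this one step, so their separate shares remain unknown. From the compounds shown here alone, whether an amine or a carboxylic acid could replace the hydroxyl of the 2-hydroxyethyl chain also stays open.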